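Lengthening the chain: what to expect of compound 3

The compounds below may be only part of what the source reports. "The series", "measured", "known", "first", "only" and "open" are said of these compounds alone.

Compound 1 `CCCCCCc1ccc(-c2c(C)[nH]c(=O)n2C)cc1` gives 9000 nM
Compound 2 `CCCCCCCCc1ccc(-c2c(C)[nH]c(=O)n2C)cc1` gives 19400 nM

In a functional assay on brain (Rattus norvegicus, strain Wistar) for inhibition (on this read-out higher numbers stand for weaker inhibition and lower numbers for stronger inhibition), compound 2 has the higher of the two numbers, which makes it the weaker inhibitor of the pair. Compound 3 `CCCCCCCCCCCCCCc1ccc(-c2c(C)[nH]c(=O)n2C)cc1` differs from it by hexyl in place of hydrogen on a saturated chain carbon, eight bonds along the chain from an aromatic carbon and is still unmeasured. Going by the values given here, one measured step bears on this, a shorter extension of the same chain, showing a 2.2-fold higher number from compound 1 to compound 2 (0.33 log units; beyond the scatter) as a modest rise. The new extension is longer, so a further rise is expected, though one step is thin evidence. The estimate is a 2.6-fold higher number from compound 2 to compound 3 (0.41 log units; beyond the scatter) in the same direction. Compound 3 is expected at 50000 nM with an estimated range from 12000 nM to 200000 nM in this measurement.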

Compound 3, half-maximal inhibitory concentration: 43800 nM
The estimate for compound 3 lay 1.1-fold (0.06 log units) above the measured number; the measured number falls inside the stated range.
By their numbers in this assay, from the lowest: compound 1; then compound 2; then compound 3.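

In this assay, the rise continues beyond compound 2: adding hexyl at this place gives a 2.3-fold higher number from compound 2 to compound 3 (0.35 log units; beyond the scatter), so inhibition weakens again. Across all three compounds, the octyl extension gives a 4.9-fold higher number from compound 1 to compound 3 (0.69 log units; beyond the scatter), and none of them goes against this trend. Nothing measured here explains the trend. The compounds shown leave open whether a shorter chain such as butyl would give a lower number than compound 1. They also leave open whether an amine or a carboxylic acid at the end of the chain would alter the trend.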